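This account rests on a few compounds, and the source may have more. Where it says the series, first, only, none or still open, it means among the compounds named here.

The measured compounds and their values in a functional assay on HT-29 cells (Homo sapiens) for antiproliferative activity, read by MTT assay, with a stated time of 72 h; on this read-out higher numbers stand for weaker inhibition and lower numbers for stronger inhibition:

compound 1, `COc1cc2c(Oc3ccc(NC(=O)c4nc(-c5ccc(F)cc5)no4)cc3)ccnc2cc1OCCCN1CCC(C)CC1`, gives 6380 nM
compound 2, `COc1cc2c(Oc3ccc(NC(=O)C4(c5nnc(-c6ccc(F)cc6)o5)CC4)cc3F)ccnc2cc1OCCCN1CCCC1`, gives 779 nM
compound 3, `COc1cc2nccc(Oc3ccc(NC(=O)c4nnc(-c5ccc(F)cc5)o4)cc3)c2cc1OC`, gives 52300 nM

Among these three numbers compound 1 stands second highest. Its nearest neighbour is compound 2, whose number is lower by a margin beyond the usual scatter, and the furthest is compound 3, whose number is higher by a margin that also lies beyond the scatter. No pair among these three differs in only one place, so the three values show where each compound lies but no single change can be read from them.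

Compound 4, `COc1cc2c(Oc3ccc(NC(=O)c4ncc(-c5ccc(F)cc5)o4)cc3)ccnc2cc1OCCCN1CCC(C)CC1`, has not yet been measured in this assay. It differs from compound 1 in one place only: 5-(4-fluorophenyl)-1,3-oxazol-2-yl in place of 3-(4-fluorophenyl)-1,2,4-oxadiazol-5-yl on a carbonyl carbon. The rest of the core of compound 1, including the amide and the chain ending in the 4-methylpiperidine, stays as it is.

For the measured compounds named here, nothing among the measured compounds isolates this kind of exchange of the five-membered ring, so the expectation rests on compound 1 alone. The step from compound 1 to compound 4 is estimated to be small, a 1.4-fold lower number from compound 1 to compound 4 (0.15 log units; within the scatter), within the scatter rather than a clear move in either direction. Compound 4 is therefore expected to give about 4500 nM, with a range from 1100 nM to 18000 nM.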

Compound 4, half-maximal inhibitory concentration: 1890 nM
For compound 4 the middle estimate is 2.4-fold (0.38 log units) above the measured one, and the stated range covers the measured number.
By their numbers in this assay, from the lowest: compound 2; then compound 4; then compound 1; then compound 3.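

In this assay, for the compounds shown here, the exchange of 3-(4-fluorophenyl)-1,2,4-oxadiazol-5-yl for 5-(4-fluorophenyl)-1,3-oxazol-2-yl on the carbonyl carbon is the first change that can be read on its own, and it gives a 3.4-fold lower number from compound 1 to compound 4 (0.53 log units; beyond the scatter), a modest step that lies beyond the scatter. The number therefore responds to the make-up of the five-membered ring at this position, even though the 4-fluorophenyl group, the amide and the chain ending in the 4-methylpiperidine all stay the same, and the two groups match in heavy-atom count and differ in having 2 hydrogen-bond acceptors in the entering group against 3 in the leaving one. Nothing measured here accounts for the step, so it stands as an observation without an explanation.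

Going by these compounds alone, with only this one exchange, it remains open whether another ring on the same carbonyl carbon, such as 1,3-thiazol-2-yl, would lower the number further or raise it again. On these data alone, it is also open whether the step would carry over when a morpholine replaces the 4-methylpiperidine at the end of the chain, or when a plain phenyl replaces the 4-fluorophenyl.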